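Nitrogen substitution on compound 3

The source may hold more compounds than are shown below. What is called first, only, known or untested is meant among the compounds shown, and "the series" means these compounds.

Measured in a functional assay on MIA PaCa-2 cells (Homo sapiens) for cytotoxicity, read by WST assay, with a stated time of 24 h; on this read-out higher numbers stand for weaker inhibition and lower numbers for stronger inhibition:
- compound 1 `COc1ccc2c(/C=C(\C#N)C(=O)c3c[nH]c4cc(OC)ccc34)c[nH]c2c1`: > 50000 nM (a limit)
- compound 2 `COc1ccc2c(C(=O)/C(C#N)=C/c3cn(Cc4ccc(Cl)cc4)c4ccccc34)c[nH]c2c1`: > 50000 nM (a limit)
- compound 3 `COc1ccc2c(C(=O)/C(C#N)=C/c3c[nH]c4ccccc34)c[nH]c2c1`: 13500 nM

Going by the values given here, compound 3 gives the only actual number in this assay, 13500 nM. The other two compounds give only a limit: the limit of > 50000 nM in this assay, at which 2 of the 3 values shown sit.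

Compound 4 `COc1ccc(Cn2cc(/C=C(\C#N)C(=O)c3c[nH]c4cc(OC)ccc34)c3ccccc32)cc1` differs from compound 3 as follows: 4-methoxybenzyl in place of hydrogen on an aromatic nitrogen. In words, 4-methoxybenzyl stands in place of hydrogen on an aromatic nitrogen.

The step that bears most directly on this change is an at least 3.7-fold lower number from compound 2 to compound 3 (0.56 log units; beyond the scatter). It also exchanges hydrogen and a substituted benzyl on an aromatic nitrogen, but runs in the opposite direction. The other measured step, an at least 3.7-fold lower number from compound 1 to compound 3 (0.56 log units; beyond the scatter), concerns an aromatic carbon and bears on this change only indirectly. Read in reverse, the first step points to a higher number, beyond the scatter, although its true size is unknown. The expected step in this assay is a 2.8-fold higher number from compound 3 to compound 4 (0.45 log units; beyond the scatter). For compound 4 the estimate is 38000 nM, with an expected range of 11000 nM to 100000 nM.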

Compound 4, half-maximal inhibitory concentration: > 50000 nM
Compound 4: no number, only a limit; the forecaster's own chance of this, stated with the estimate: 60%; at least 1.3-fold (0.11 log units) between middle value and limit.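

In this assay, putting 4-methoxybenzyl on the aromatic nitrogen gives an at least 3.7-fold higher number from compound 3 to compound 4 (0.56 log units; beyond the scatter) as its result, so the weaker inhibition seen for 4-chlorobenzyl through an at least 3.7-fold lower number from compound 2 to compound 3 (0.56 log units; beyond the scatter) is not confined to that one substituted benzyl. The step from compound 2 to compound 4 cannot be read: each gives only a limit, and methoxy and chloro on the benzyl group stay unranked. Compound 4 adds one more limit to this small set, leaving compound 3 as the only actual number: the limit of > 50000 nM in this assay, at which 3 of the 4 values shown sit.

Open, on these data alone, is whether a smaller group on this nitrogen, such as methyl, leaves compound 3 with its 13500 nM or moves that number. Also open, as far as these compounds go, is whether a chain ending in an amine or a carboxylic acid at this position would give an actual number rather than another limit.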